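Carbonyl substituent and lipophilicity in the shared core

This account rests on a few compounds, and the source may have more. Where it says the series, first, only, none or still open, it means among the compounds named here.

Measured so far:
compound 1 `Cc1cc(/C=C/C#N)cc(C)c1Oc1cc(Nc2ccc(C#N)cc2)c(N)cc1C(=O)NN`: 2.31
compound 2 `Cc1cc(/C=C/C#N)cc(C)c1Oc1cc(Nc2ccc(C#N)cc2)c(N)cc1C(N)=O`: 3.53

Both numbers come from a physicochemical assay for lipophilicity, read by HPLC, measured as octanol-water partition, with a stated time of 24 h, at pH 7.4; on this read-out lower numbers stand for lower lipophilicity and higher numbers for higher lipophilicity. For the measured compounds named here, compound 2 stands highest of the two measured numbers, and the only measured step, a number 1.22 log units higher from compound 1 to compound 2 (beyond the scatter), is large and beyond the scatter.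

Compound 3 `COC(=O)c1cc(N)c(Nc2ccc(C#N)cc2)cc1Oc1c(C)cc(/C=C/C#N)cc1C` is not yet measured. It differs from compound 2 by methoxy in place of amino on a carbonyl carbon, that is carbamoyl to methoxycarbonyl. Going by the values given here, the one measured step bears on it because a number 1.22 log units higher from compound 1 to compound 2 (beyond the scatter) was also a change of the substituent pattern around the carbonyl, and it moved the number upward by a large amount. A further rise in this assay beyond the scatter is therefore expected for compound 3, of roughly a number 1.27 log units higher from compound 2 to compound 3 (beyond the scatter). The estimate for compound 3 in this assay is 4.8, with a range from 4.2 to 5.4.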

Compound 3, partition coefficient: 4.15
For compound 3 the middle estimate is 0.65 log units above the measured one, outside the stated range (below it).
By their numbers in this assay, from the lowest: compound 1; then compound 2; then compound 3.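

In this assay, methoxy in place of amino on the carbonyl carbon gives a further rise (a number 0.62 log units higher from compound 2 to compound 3 (beyond the scatter)), so the read-out at this position keeps climbing past compound 2, although this modest step is smaller than the large one before it (a number 1.22 log units higher from compound 1 to compound 2 (beyond the scatter)). Across the three carbonyl substituents, the order from lowest runs aminoamino, amino, methoxy, with the full span being (a number 1.84 log units higher from compound 1 to compound 3 (beyond the scatter)), and none of the three compounds goes against that order. No measurement at hand gives a reason for the size of either step.

From the compounds shown here alone, whether a longer chain on the ester oxygen, such as ethoxy, continues the rise remains open, as does where a carboxylic acid would fall at this carbonyl carbon. A methylamino group there would show how a substituted amide compares with compound 2 and compound 3.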